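This account rests on a few compounds, and the source may have more. Where it says the series, first, only, none or still open, it means among the compounds named here.

Measured so far:
- compound 1, `Oc1cc(C(F)(F)F)ccc1-c1nc(-c2ccccc2O)n(-c2ccc(F)cc2)n1`, gives 86.7% in a functional assay on PC-12 cells (Rattus norvegicus) for cytotoxicity, read by MTT assay, with stated times of 2 h and 24 h, tested at 5 uM; a higher number here means a stronger effect of the compound at the concentration tested, a lower number a weaker effect
- compound 2, `N#Cc1ccc(-n2nc(-c3ccc(C(F)(F)F)cc3O)nc2-c2ccccc2O)cc1`, gives 86.8% in this assay
- compound 3, `Oc1cc(C(F)(F)F)ccc1-c1nc(-c2ccccc2O)n(-c2ccccc2C(F)(F)F)n1`, gives 80% in this assay

Compound 3 has the smallest of the three numbers, yet the gaps to its neighbours, a number 6.7 percentage points lower from compound 1 to compound 3 (within the scatter) and a number 6.8 percentage points lower from compound 2 to compound 3 (within the scatter), are both within the scatter, so the three compounds cannot be told apart on these data. Compound 4, `Cc1cc(C)cc(-n2nc(-c3ccc(C(F)(F)F)cc3O)nc2-c2ccccc2O)c1`, has not been measured. It differs from compound 3 in one place: 3,5-dimethylphenyl in place of 2-(trifluoromethyl)phenyl on an aromatic nitrogen. The two measured steps that bear on this are the ones that also exchange the group on the aromatic nitrogen, from compound 1 to compound 3 and from compound 2 to compound 3; both stayed within the scatter, as did the swap of cyano for fluoro, a number 0.1 percentage points higher from compound 1 to compound 2 (within the scatter). Nothing in the shared core changes. Compound 4 is therefore expected to lie close to compound 3, with an estimated step of a number 3 percentage points higher from compound 3 to compound 4 (within the scatter). The expected value for compound 4 in this assay is 83%, between 70% and 94%.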

Compound 4, a percentage reported as activity, at one concentration (the size of the read-out at that concentration, not a potency): 102%
For compound 4 the middle estimate is 19 percentage points below the measured one; measured number outside the range, above it.
By their numbers in this assay, from the lowest: compounds 3, 1 and 2 (each within the scatter of the next); then compound 4.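

The group on the aromatic nitrogen is not as silent in this assay as the earlier exchanges suggested: those stayed within the scatter, whereas 3,5-dimethylphenyl stands apart from all three other groups, with a number 22 percentage points higher from compound 3 to compound 4 (beyond the scatter) and a number 15.2 percentage points higher from compound 2 to compound 4 (beyond the scatter) and a number 15.3 percentage points higher from compound 1 to compound 4 (beyond the scatter) as the steps show. Of the four aryl groups on this nitrogen, it is the only one with neither fluorine nor a nitrile, but a single compound cannot establish that this difference is what matters. No measurement shown here explains the step.

On these data alone, whether the higher number needs both methyl groups or would persist with just one remains open. So does the outcome for a phenyl ring carrying an amine or a carboxylic acid, or for a cyclohexyl ring on this nitrogen.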